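Cyclopentenyl in Place of Cyclopentyl on the Shared Core

The source may report more compounds than this note shows. Statements on the series, on what has been measured and on what is new or still open speak of the compounds shown alone.

Compound 2 `Cc1c(C(=O)Nc2ccc(Oc3ncnc4[nH]cc(-c5ccccc5)c34)c(F)c2)c(=O)c2cc(C3CCCC3)ccc2n1C` gives 200 nM in an assay on isolated protein for inhibition of tyrosine-protein kinase receptor UFO (Homo sapiens), read by FRET and Z'-LYTE, with a stated time of 1.5 h (a higher number here means a weaker inhibitor, a lower number a stronger inhibitor), a number that stands at one end of the two shown but within the scatter of compound 1 `Cc1c(C(=O)Nc2ccc(Oc3ncnc4[nH]cc(-c5ccccc5)c34)c(F)c2)c(=O)c2cc(C(F)(F)F)ccc2n1C`, which gives 150 nM. Going by the values given here, the one measured step, a 1.3-fold higher number from compound 1 to compound 2 (0.12 log units; within the scatter), does not touch the change now considered. Compound 3 `Cc1c(C(=O)Nc2ccc(Oc3ncnc4[nH]cc(-c5ccccc5)c34)c(F)c2)c(=O)c2cc(C3=CCCC3)ccc2n1C` differs from compound 2 by cyclopent-1-en-1-yl in place of cyclopentyl on an aromatic carbon. Among the compounds with values here, no measured step bears on this change, so compound 3 is expected to move only by no change at the digits printed from compound 2 to compound 3 (within the scatter), nothing beyond the scatter. Compound 3 is therefore estimated at 200 nM in this assay, with a range from 90 nM to 450 nM.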

Compound 3, half-maximal inhibitory concentration: 3320 nM
For compound 3 the middle estimate is 17-fold (1.22 log units) below the measured one; the measured number lies above the stated range.
By their numbers in this assay, from the lowest: compounds 1 and 2 (each within the scatter of the next); then compound 3.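

At this aromatic carbon, the two five-membered rings are not interchangeable: in this assay, cyclopent-1-en-1-yl, with its double bond outside aromatic rings, gives a much weaker inhibitor than cyclopentyl (a 17-fold higher number from compound 2 to compound 3 (1.22 log units; beyond the scatter)). Trifluoromethyl and cyclopentyl lie within the scatter of each other, yet cyclopent-1-en-1-yl also stands apart from trifluoromethyl (a 22-fold higher number from compound 1 to compound 3 (1.35 log units; beyond the scatter)). No evidence is available to explain this separation. As far as these compounds go, whether a cyclohexyl ring or a morpholine at this carbon would stay near compound 2 remains open, as does whether the same step would recur on another core.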